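The source may hold more compounds than are shown below. What is called first, only, known or untested is meant among the compounds shown, and "the series" means these compounds.

The series shares one core, seen in compound 1 `S=C(Nc1ccccc1)N1N=C(c2ccccc2)CC1c1ccc2c(c1)OCCO2`, and varies the aromatic group on the carbon with a double bond to nitrogen. In a functional assay on HT-29 cells (Homo sapiens) for antiproliferative activity, read by MTT assay, with a stated time of 48 h (on this read-out higher numbers stand for weaker inhibition of growth and lower numbers for stronger inhibition of growth), compound 1 gives 6630 nM. Among the compounds with values here, compound 2 `S=C(Nc1ccccc1)N1N=C(c2ccc(Br)cc2)CC1c1ccc2c(c1)OCCO2` gives 2580 nM in this assay, the lowest of the three numbers measured so far, and compound 3 `COc1ccccc1C1=NN(C(=S)Nc2ccccc2)C(c2ccc3c(c2)OCCO3)C1` gives 30500 nM in this assay. The two steps that involve compound 2 point in opposite directions: a 2.6-fold lower number from compound 1 to compound 2 (0.41 log units; beyond the scatter), whereas a 12-fold higher number from compound 2 to compound 3 (1.07 log units; beyond the scatter). Compound 4 `Cc1ccc(C2=NN(C(=S)Nc3ccccc3)C(c3ccc4c(c3)OCCO4)C2)cc1C` differs from compound 2 in one place: 3,4-dimethylphenyl in place of 4-bromophenyl on a carbon with a double bond to nitrogen. Within the data shown here, no measured step sets a 3,4-dimethylphenyl group against a 4-bromophenyl group, so the outcome cannot be read off directly; the step of a 2.6-fold lower number from compound 1 to compound 2 (0.41 log units; beyond the scatter) shows that a substituent on this ring can lower the number, while a 12-fold higher number from compound 2 to compound 3 (1.07 log units; beyond the scatter) shows a different one can raise it sharply. For compound 4 a modest step is expected, a 1.6-fold higher number from compound 2 to compound 4 (0.19 log units; within the scatter), not far beyond the scatter. The estimate for compound 4 in this assay is 4000 nM, within a range from 1500 nM to 12000 nM.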

Compound 4, concentration for 50% growth inhibition: 133000 nM
Beside the measured number, compound 4's estimate is 33-fold (1.52 log units) below it; measured number outside the range, above it.
By their numbers in this assay, from the lowest: compound 2; then compound 1; then compound 3; then compound 4.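

In this assay, compound 4 gives the highest number of the four, which shows that this position can tolerate even less than the 2-methoxyphenyl group of compound 3 had suggested (a 4.4-fold higher number from compound 3 to compound 4 (0.64 log units; beyond the scatter)). The change from 4-bromophenyl to 3,4-dimethylphenyl is the largest step in the set (a 52-fold higher number from compound 2 to compound 4 (1.71 log units; beyond the scatter)), and the 3,4-dimethylphenyl group also stands well above the plain phenyl group (a 20-fold higher number from compound 1 to compound 4 (1.30 log units; beyond the scatter)). Of the three substituted rings, only the 4-bromophenyl group of compound 2 lowers the number relative to compound 1, while those of compound 3 and compound 4 both raise it.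

From the compounds shown here alone, whether a phenyl ring bearing a single methyl group, a chlorine or an amine would follow compound 2 or compound 4 remains open. Nothing available here accounts for the size of these steps.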